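The compounds below may be only part of what the source reports. "The series", "measured", "known", "first", "only" and "open" are said of these compounds alone.

In a functional assay on cells (T-cell line, Homo sapiens) for inhibition (a higher number here means a weaker inhibitor, a lower number a stronger inhibitor), compound 1 `Clc1ccc(CCCN2CCC(COC(c3ccccc3)c3ccccc3)CC2)cc1` gives 500 nM and compound 2 `Clc1ccc(CCCN2CCC(COC(c3ccccc3)c3ccccc3)CC2)cc1Cl` gives 2200 nM, the higher of the two numbers. Compound 3 `CCCCN1CCC(COC(c2ccccc2)c2ccccc2)CC1` differs from compound 2 by methyl in place of 3,4-dichlorophenyl on a saturated chain carbon, three bonds along the chain from an amine nitrogen in a ring, with methyl in place of 3,4-dichlorophenyl on a saturated chain carbon. Within the data shown here, only one measured step bears on this: a 4.4-fold higher number from compound 1 to compound 2 (0.64 log units; beyond the scatter), a modest step that covers chloro in place of hydrogen alone. Among the measured compounds shown here, no measured compound lacks the aromatic ring, so the uncertainty is wide. The expected step in this assay, a 1.5-fold lower number from compound 2 to compound 3 (0.17 log units; within the scatter), is none beyond the scatter. For compound 3 the estimate is 1500 nM, with an expected range of 300 nM to 7000 nM.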

Compound 3, half-maximal inhibitory concentration: 14000 nM
The estimate for compound 3 lay 9.3-fold (0.97 log units) below the measured number, outside the stated range (above it).
By their numbers in this assay, from the lowest: compound 1; then compound 2; then compound 3.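

In this assay the aromatic group on the saturated chain carbon, three bonds along the chain from an amine nitrogen in a ring, counts for more than the chloro change did: methyl in place of 3,4-dichlorophenyl gives a 6.4-fold higher number from compound 2 to compound 3 (0.80 log units; beyond the scatter) as the step, and methyl in place of 4-chlorophenyl gives a 28-fold higher number from compound 1 to compound 3 (1.45 log units; beyond the scatter) as the step. Even the dichloro compound, the weaker of the two aryl compounds, stays clearly stronger than the methyl end. No measurement at hand accounts for this.

On these data alone, whether an unsubstituted phenyl at this position holds the gain remains open. Also open, as far as these compounds go, is whether the ring itself matters or only the chain length, which a longer alkyl chain or a cyclohexyl group would help to separate.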